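The source may hold more compounds than are shown below. What is called first, only, known or untested is meant among the compounds shown, and "the series" means these compounds.

Of the compounds shown here, three that share one core have been measured in a functional assay on MCF7 cells (Homo sapiens) for inhibition, read by MTT assay, with a stated time of 72 h; a higher number here means a weaker inhibitor of growth, a lower number a stronger inhibitor of growth. Compound 1 `O=S(=O)(NCCNCc1cccc2ccccc12)c1cc(C(F)(F)F)cc(C(F)(F)F)c1` gives 18000 nM. Compound 2 `O=S(=O)(NCCCCNCc1ccc(Br)cc1)c1cc(C(F)(F)F)cc(C(F)(F)F)c1` gives 1500 nM. Compound 3 `O=S(=O)(NCCCNCc1ccc(Cl)c(C(F)(F)F)c1)c1cc(C(F)(F)F)cc(C(F)(F)F)c1` gives 3500 nM, which places compound 3 second highest of the three numbers: its nearest neighbour is compound 2, whose number is lower by a margin beyond the usual scatter, and its furthest is compound 1, whose number is higher by a still larger margin, also beyond the scatter.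

The next compound, compound 4 `O=S(=O)(NCCCNCc1cccc2ccccc12)c1cc(C(F)(F)F)cc(C(F)(F)F)c1`, differs from compound 3 in one place: naphthalen-1-yl in place of 4-chloro-3-(trifluoromethyl)phenyl on a saturated chain carbon bound to an amine nitrogen. Within the data shown here, no directly comparable pair among the measured compounds isolates this change, so its effect in this assay is not known from a single step. Among the measured compounds shown here, the only other compound carrying naphthalen-1-yl is compound 1, with a shorter chain and the highest number of the three; the chain length of compound 4 matches that of compound 3.

On that basis compound 4 is expected to give a higher number than compound 3, with a step from compound 3 to compound 4 estimated at a 2.3-fold higher number from compound 3 to compound 4 (0.36 log units; beyond the scatter) in this assay, of moderate size and probably beyond the scatter. Compound 4 is therefore estimated at 8000 nM, within a range from 3000 nM to 25000 nM.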

Compound 4, concentration for 50% growth inhibition: 1400 nM
The estimate for compound 4 lay 5.7-fold (0.76 log units) above the measured number; measured number below the stated range.
By their numbers in this assay, from the lowest: compounds 4 and 2 (each within the scatter of the next); then compound 3; then compound 1.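

In this assay, among these compounds, naphthalen-1-yl in place of 4-chloro-3-(trifluoromethyl)phenyl on a saturated chain carbon bound to an amine nitrogen gives a 2.5-fold lower number from compound 3 to compound 4 (0.40 log units; beyond the scatter), a modest step and the first reading of this change with the chain held the same. It shows that this position accepts two six-membered aromatic rings of carbon only in place of one ring bearing chlorine and trifluoromethyl, with no loss in growth inhibition. It also means the high number of compound 1 cannot be read as a mark of naphthalen-1-yl alone, since that group on a shorter chain in compound 1 gives 18000 nM, while the same group in compound 4 gives 1400 nM.

Nothing measured here speaks to why the exchange lowers the number, whether through the second ring or through the loss of the chlorine and trifluoromethyl groups. Still open, as far as these compounds go, is how naphthalen-2-yl or a plain phenyl would read at this position, and whether a longer chain carrying naphthalen-1-yl would move the number further in either direction.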